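The compounds below may be only part of what the source reports. "The series", "measured", "known", "first", "only" and "open" are said of these compounds alone.

In a functional assay on HL-60 cells (Homo sapiens) for antiproliferative activity (on this read-out lower numbers stand for stronger inhibition and higher numbers for weaker inhibition), compound 1 `C=C1C(=O)ON(C)C1C(C)C` gives 740 nM, while compound 2 `C=C1C(=O)ON(C)C1c1ccccc1` gives 34800 nM, the higher of the two numbers, a gap beyond the usual scatter, so compound 2 is the weaker inhibitor of the pair. Compound 3 `C=C1C(=O)ON(C)C1c1ccc(C)cc1` keeps everything of compound 2 and carries a single change, methyl in place of hydrogen on an aromatic carbon. Going by the values given here, no measured pair shows what this change does here, so in this assay no step beyond the scatter is expected, in either direction. Compound 3 is therefore estimated at 30000 nM, between 10000 nM and 90000 nM, the expected shift being a 1.2-fold lower number from compound 2 to compound 3 (0.06 log units; within the scatter).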

Compound 3, half-maximal inhibitory concentration: 5400 nM
Beside the measured number, compound 3's estimate is 5.6-fold (0.74 log units) above it; the measured number lies below the stated range.
By their numbers in this assay, from the lowest: compound 1; then compound 3; then compound 2.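

In this assay, putting methyl in place of hydrogen on an aromatic carbon gives a 6.4-fold lower number from compound 2 to compound 3 (0.81 log units; beyond the scatter) and so stronger inhibition, a modest step but one beyond the scatter. This position on the six-membered aromatic ring therefore responds to a change as small as 1 carbon, para to a group of 8 heavy atoms. Nothing available here explains the step. Still open, from the compounds shown here alone, is whether a longer chain such as ethyl would extend the gain at this position. An amine or a carboxylic acid there could equally keep it or lose it.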